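Fluoro in Place of Methyl on Compound 3

This account rests on a few compounds, and the source may have more. Where it says the series, first, only, none or still open, it means among the compounds named here.

In an ADME assay on RAW264.7 cells (Mus musculus) for cytotoxicity, read by MTT assay, with a stated time of 48 h (a higher number here means that more compound is tolerated, a lower number that less compound is tolerated), compound 3 (`C#CCN(c1nc(-c2ccc(C)cc2)no1)C1CCCCC1`) gives 17.6 ug/mL. Compound 1 (`CC(=O)OC[C@H]1O[C@H](OC[C@H](Cn2cc(COc3ccc(-c4noc(NC5CCCCC5)n4)cc3)nn2)OC(C)=O)C=C[C@@H]1OC(C)=O`) gives 33.3 ug/mL, which lies within the scatter of compound 3. Compound 2 (`CC(=O)OC[C@H]1O[C@H](OC[C@@H](Cn2cc(CN(c3nc(-c4cccc([N+](=O)[O-])c4)no3)C3CCCCC3)nn2)OC(C)=O)C=C[C@@H]1OC(C)=O`) gives 100 ug/mL, a gap from compound 3 that lies beyond the scatter. Compounds 1 and 2 are much larger structures, however, and neither is a close neighbour of compound 3.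

Compound 4 (`C#CCN(c1nc(-c2ccc(F)cc2)no1)C1CCCCC1`) departs from compound 3 in one place: fluoro in place of methyl on an aromatic carbon. This puts fluoro in place of methyl on an aromatic carbon, para to a large group, turning 4-methylphenyl into 4-fluorophenyl.

Going by the values given here, no two measured compounds differ in one place only, and the data therefore offer no direct precedent for this change. The expected step of a 1.1-fold higher number from compound 3 to compound 4 (0.06 log units; within the scatter) stays within the scatter, with no firm direction, and the estimate rests on compound 3 at 17.6 ug/mL. In this assay, compound 4 is estimated at 20 ug/mL, with an expected range of 9 ug/mL to 45 ug/mL.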

Compound 4, half-maximal cytotoxic concentration: 20.9 ug/mL
For compound 4 the middle estimate is 1.0-fold (0.02 log units) below the measured one; the range from low to high includes it.
By their numbers in this assay, from the lowest: compounds 3, 4 and 1 (each within the scatter of the next); then compound 2.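

In this assay, going by these compounds alone, the exchange of methyl for fluoro gives the first direct comparison at this position, with a 1.2-fold higher number from compound 3 to compound 4 (0.07 log units; within the scatter) as its step. On this aromatic carbon, para to a large group, 4-methylphenyl and 4-fluorophenyl therefore cannot be told apart in this one pair, so the exchange has no firm direction here. Nothing given here bears on what lies behind this result.

The compounds shown leave open whether another group at the same place, such as an amine, a carboxylic acid or a longer chain, would give a step beyond the scatter. They also leave open whether fluoro in place of methyl would read the same way on a larger structure.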